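Benzoate ester series: chlorine pattern on the ester aryl ring

This account rests on a few compounds, and the source may have more. Where it says the series, first, only, none or still open, it means among the compounds named here.

Measured so far:
- compound 1, `CC1=CC[C@H]2[C@H](CC[C@]2(C)O)C(C)(C)[C@@H]1CC[C@H]1[C@]2(C)CC[C@H](OC(=O)c3ccccc3)C(C)(C)O[C@H]2CC[C@@]1(C)O`: 21000 nM
- compound 2, `CC1=CC[C@H]2[C@H](CC[C@]2(C)O)C(C)(C)[C@@H]1CC[C@H]1[C@]2(C)CC[C@H](OC(=O)c3ccc(Cl)c(Cl)c3)C(C)(C)O[C@H]2CC[C@@]1(C)O`: 11900 nM

Both numbers come from a functional assay on MCF7 cells (Homo sapiens) for antiproliferative activity, read by MTT assay, with a stated time of 72 h; a lower number here means a stronger inhibitor, a higher number a weaker inhibitor. For the measured compounds named here, compound 2 holds the lowest of the two numbers, but its only neighbour is compound 1, and the single measured step, a 1.8-fold lower number from compound 1 to compound 2 (0.25 log units; within the scatter), does not leave the scatter, so no order between compound 1 and compound 2 can be claimed.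

Compound 3, `CC1=CC[C@H]2[C@H](CC[C@]2(C)O)C(C)(C)[C@@H]1CC[C@H]1[C@]2(C)CC[C@H](OC(=O)c3ccccc3Cl)C(C)(C)O[C@H]2CC[C@@]1(C)O`, is not yet measured. It differs from compound 2 in one place: 2-chlorophenyl in place of 3,4-dichlorophenyl on a carbonyl carbon. Going by the values given here, the only step that bears on it is a 1.8-fold lower number from compound 1 to compound 2 (0.25 log units; within the scatter), which shows that adding two chlorines to the phenyl stayed within the scatter. Moving to a single chlorine is therefore expected to give no step beyond the scatter in this assay, and the expected step of a 1.3-fold higher number from compound 2 to compound 3 (0.10 log units; within the scatter) is set close to no change, leaning toward the value of compound 1. For compound 3 the estimate in this assay is 15000 nM, with a range from 6000 nM to 40000 nM.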

Compound 3, half-maximal inhibitory concentration: 12100 nM
Beside the measured number, compound 3's estimate is 1.2-fold (0.09 log units) above it; low and high end bracket the measured number.
By their numbers in this assay, from the lowest: compounds 2, 3 and 1 (each within the scatter of the next).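

In this assay, 2-chlorophenyl in place of 3,4-dichlorophenyl on a carbonyl carbon gives a 1.0-fold higher number from compound 2 to compound 3 (0.01 log units; within the scatter), and chloro in place of hydrogen on an aromatic carbon gives a 1.7-fold lower number from compound 1 to compound 3 (0.24 log units; within the scatter). Both steps lie within the scatter, so a single chlorine and the 3,4-dichloro pattern cannot be told apart here, and neither can be told apart from the unsubstituted phenyl, which leaves no order among the three benzoates. No measured evidence accounts for this flat result.

Still open, going by these compounds, is whether an aryl ring bearing an amine or a carboxylic acid, or a longer chain in place of the aryl ring on the carbonyl carbon, would give a step beyond the scatter. The compounds shown also leave open whether this ester position can shift the number at all on the shared core.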